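Notes on the step from compound 3 to compound 4

This account rests on a few compounds, and the source may have more. Where it says the series, first, only, none or still open, it means among the compounds named here.

- compound 1 `CC[C@@H](Nc1c(C#N)c(-c2ccc(-c3cccc(Cl)c3OC)cc2)nc2cnccc12)C(N)=O`: 3.1
- compound 2 `CC[C@@H](Nc1c(C#N)c(-c2ccc(-c3cccnc3C)cc2)nc2cnccc12)C(N)=O`: 1.9
- compound 3 `CC[C@@H](Nc1c(C#N)c(-c2ccc(-c3ccccc3C(F)(F)F)cc2)nc2cnccc12)C(N)=O`: 3.1

In a physicochemical assay for lipophilicity, read by HPLC, at pH 7.5 (on this read-out lower numbers stand for lower lipophilicity and higher numbers for higher lipophilicity), compound 3 gives 3.1, level with compound 1, and together they hold the highest number of the three. Compound 4 `CC[C@@H](Nc1c(C#N)c(-c2ccc(-c3cccc(OC)c3)cc2)nc2cnccc12)C(N)=O` follows with 3-methoxyphenyl in place of 2-(trifluoromethyl)phenyl on an aromatic carbon, para to a large group. The closest guide is no change at the digits printed from compound 1 to compound 3 (within the scatter), a phenyl-for-phenyl exchange. The large steps, a number 1.20 log units lower from compound 1 to compound 2 (beyond the scatter) and a number 1.20 log units higher from compound 2 to compound 3 (beyond the scatter), both involve 2-methylpyridin-3-yl, which is absent here. The expected step is a number 0.20 log units lower from compound 3 to compound 4 (within the scatter), slightly downward and not expected to exceed the scatter. For compound 4 the estimate is 2.9, with an expected range of 2.5 to 3.2.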

Compound 4, distribution coefficient: 2.7
Estimate against measurement, compound 4: 0.20 log units above; low and high end bracket the measured number.
By their numbers in this assay, from the lowest: compound 2; then compound 4; then compounds 1 and 3 (each within the scatter of the next).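

In this assay the phenyl groups at this place no longer sit at one level: the series shows a number 0.40 log units lower from compound 3 to compound 4 (beyond the scatter) and also a number 0.40 log units lower from compound 1 to compound 4 (beyond the scatter) even though compound 1 and compound 3 match. The pyridine still stands apart, with a number 0.80 log units higher from compound 2 to compound 4 (beyond the scatter) as a smaller step than those separating it from compound 1 and compound 3. No measurement in hand explains these steps.

Open, from the compounds shown here alone, is whether 3-methoxyphenyl differs from 2-(trifluoromethyl)phenyl through the group or through its place on the ring. Going by these compounds, how an amine or a carboxylic acid on this phenyl ring would read also remains open.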